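The compounds below may be only part of what the source reports. "The series", "measured", "known", "first", "only" and "open" are said of these compounds alone.

Compound 1, with the structure `CCC(C)C(N)c1cc(C(F)(F)F)ccc1N1CCN(C(=O)CCc2ccc(Cl)cc2Cl)CC1`, was tested in an assay on HEK293 cells for displacement of a labelled ligand from Melanocortin receptor 4 (Homo sapiens) (a lower number here means a stronger inhibitor, a higher number a weaker inhibitor), and gave 160 nM. Two related compounds give the setting. Compound 2, `CCC(C)[C@H](N)c1cc(C(F)(F)F)ccc1N1CCN(C(=O)CCc2ccc(OC)cc2Cl)CC1`, gives 57 nM in this assay, and compound 3, `CC(C)C[C@H](N)c1cc(C(F)(F)F)ccc1N1CCN(C(=O)CCc2cccc(C(F)(F)F)c2)CC1`, gives 2200 nM. Among these three numbers compound 1 holds the second highest: the nearest is compound 2, whose number is lower by a margin beyond the scatter, and the furthest is compound 3, whose number is far higher, also beyond the scatter.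

The next compound, compound 4, has the structure `COCCN[C@@H](CC(C)C)c1cc(C(F)(F)F)ccc1N1CCN(C(=O)CCc2ccc(Cl)cc2Cl)CC1` and has not yet been measured. It differs from compound 1 in one place: 1-((2-methoxyethyl)amino)-3-methylbutyl in place of 1-amino-2-methylbutyl on an aromatic carbon. The group that enters is larger, carries one more hydrogen-bond acceptor and has a defined stereocentre. Going by the values given here, no measured pair shows this exact change, so the expectation rests on compound 1 alone. The step from compound 1 to compound 4 in this assay is expected to be small, leaning toward a weaker inhibitor, about a 1.6-fold higher number from compound 1 to compound 4 (0.19 log units; within the scatter). Compound 4 is therefore estimated at 250 nM, within a range from 60 nM to 1000 nM.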

Compound 4, inhibition constant: 620 nM
For compound 4 the middle estimate is 2.5-fold (0.39 log units) below the measured one; the range from low to high includes it.
By their numbers in this assay, from the lowest: compound 2; then compound 1; then compound 4; then compound 3.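

In this assay, the change at this position gives a 3.9-fold higher number from compound 1 to compound 4 (0.59 log units; beyond the scatter), so a larger group on this aromatic carbon, ortho to a large group, still leaves a measurable inhibitor, though a weaker one by a margin beyond the scatter. This single step cannot be assigned to one feature, as the entering 1-((2-methoxyethyl)amino)-3-methylbutyl group adds the 2-methoxyethyl group on the nitrogen, shifts the methyl branch along the chain and has a defined stereocentre. No measurement is available that accounts for the size or direction of this step.

The compounds shown leave open how the step divides among these features. A methylamino or 2-hydroxyethylamino group on the 2-methylbutyl chain of compound 1 would test whether substitution on the nitrogen alone weakens inhibition.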